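Swapping furan for dimethyloxazole on a non-cytotoxic series

This account rests on a few compounds, and the source may have more. Where it says the series, first, only, none or still open, it means among the compounds named here.

Compound 1 `COc1cc2[nH]c(C)c(-c3cccnc3)c(=O)c2cc1Cl`: > 33300 nM, a limit
Compound 2 `COc1cc2[nH]c(C)c(-c3cncnc3)c(=O)c2cc1Cl`: > 33100 nM, a limit
Compound 3 `COc1cc2[nH]c(C)c(-c3ccco3)c(=O)c2cc1Cl`: > 34500 nM, a limit

All three compounds were tested in an ADME assay on J774 cells (Mus musculus) for cytotoxicity, with a stated time of 72 h (a lower number here means that less compound is needed, a higher number that more compound is needed for the effect), and none of them gave a number. Compound 3 stands at > 34500 nM, which is only a limit, and the other two values beside it are limits as well.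

The next compound is compound 4 `COc1cc2[nH]c(C)c(-c3c(C)noc3C)c(=O)c2cc1Cl`, which carries 3,5-dimethyl-1,2-oxazol-4-yl in place of furan-2-yl on an aromatic carbon. The new group sits ortho to a methyl group.

Among the measured compounds shown here, three measured steps bear on this change, each an exchange of one aromatic ring on the shared core: a step that the two limits leave unreadable from compound 1 to compound 3, a step that the two limits leave unreadable from compound 2 to compound 3 and a step that the two limits leave unreadable from compound 1 to compound 2. None of them has a readable size or direction. For the measured compounds named here, nothing measured so far therefore points to a shift, and in this assay no step beyond the scatter is expected, with no direction favoured. The expected change is an at least 1.0-fold lower number from compound 3 to compound 4 (0.01 log units; that floor lies within the scatter). Most likely the result for compound 4 will again be reported only as a limit. Compound 4 is estimated at 33000 nM, with an expected range from 15000 nM to 60000 nM.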

Compound 4, half-maximal effective concentration: > 31400 nM
Compound 4 was reported as a limit (the forecaster's own chance of this, stated with the estimate: 85%); the middle value does not contradict the limit.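

In this assay compound 4, like compound 1, compound 2 and compound 3, is reported only as a limit, and none of the steps to compound 4 can be read in size or direction. The compounds shown leave open at what concentration any of them reaches the half-maximal effect, and whether exchanging the aromatic ring on the shared core changes it.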